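The source may hold more compounds than are shown below. What is called first, only, known or untested is meant among the compounds shown, and "the series" means these compounds.

Compound 1 `O=C(O)Cc1sc(C(c2ccc(F)cc2)c2ccc(F)cc2)nc1-c1ccoc1`, compound 2 `O=C(O)Cc1sc(C(c2ccc(F)cc2)c2ccc(F)cc2)nc1-c1cccc(F)c1` and compound 3 `N#Cc1ccc(-c2nc(C(c3ccc(F)cc3)c3ccc(F)cc3)sc2CC(=O)O)cc1` share one core and differ only in the ring group attached to it. In an in vitro functional assay on HEK285-7 cells for antagonist activity at prostaglandin D2 receptor 2 (Homo sapiens), read by BRET and beta-arrestin recruitment (on this read-out higher numbers stand for weaker inhibition and lower numbers for stronger inhibition), compound 1 gives 130 nM, compound 2 gives 18 nM and compound 3 gives 1500 nM. Compound 3 thus stands highest of the three numbers, meaning the weakest inhibition: the measured steps show a 12-fold higher number from compound 1 to compound 3 (1.06 log units; beyond the scatter) and an 83-fold higher number from compound 2 to compound 3 (1.92 log units; beyond the scatter), while between the two stronger compounds there is a 7.2-fold lower number from compound 1 to compound 2 (0.86 log units; beyond the scatter). Compound 4 `O=C(O)Cc1sc(C(c2ccc(F)cc2)c2ccc(F)cc2)nc1-c1ccnc(O)c1` has not yet been measured in this assay. It differs from compound 3 in one place: 2-hydroxypyridin-4-yl in place of 4-cyanophenyl on an aromatic carbon. The two measured steps that bear on this change are the ones leading into compound 3, and both are large; each shows that a different ring in this position gives a number lower than that of compound 3, well beyond the scatter. Going by the values given here, the 2-hydroxypyridin-4-yl group has no counterpart among the measured compounds, so the size of the move is uncertain, though a lower number than compound 3 is the more likely direction. Compound 4 is therefore expected to show a 5.0-fold lower number from compound 3 to compound 4 (0.70 log units; beyond the scatter) in this assay. The estimate for compound 4 is 300 nM, with a range from 50 nM to 2000 nM.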

Compound 4, half-maximal inhibitory concentration: 890 nM
The estimate for compound 4 lay 3.0-fold (0.47 log units) below the measured number; the measured number falls inside the stated range.
By their numbers in this assay, from the lowest: compound 2; then compound 1; then compounds 4 and 3 (each within the scatter of the next).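

In this assay, replacing 4-cyanophenyl with 2-hydroxypyridin-4-yl gives a 1.7-fold lower number from compound 3 to compound 4 (0.23 log units; within the scatter), so two six-membered aromatic rings with different atoms and different hydrogen-bond counts cannot be told apart here. Compound 4 also stays well apart from the two stronger compounds, with a 49-fold higher number from compound 2 to compound 4 (1.69 log units; beyond the scatter) and a 6.8-fold higher number from compound 1 to compound 4 (0.84 log units; beyond the scatter), which shows that the earlier drop in number from compound 3 does not extend to every other ring at this position: compound 4 is the exception among the three rings now compared with the 4-cyanophenyl of compound 3. No measurement available here gives a reason for this result.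

From the compounds shown here alone, what separates the 3-fluorophenyl of compound 2 from the rings of compound 3 and compound 4 remains open, since the ring and its substituent both change in these comparisons. A plain phenyl, a 4-fluorophenyl or a 3-cyanophenyl at this position would help show whether the substituent or its place on the ring matters more, and a 2-methoxypyridin-4-yl would test the hydroxy group of compound 4.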